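Swapping bromo for fluoro on the outer phenyl ring

A few compounds are considered here, and "the series" means these few. Any claim that something is new, unique, unknown or untested is made for them only; others in the source may bear on it.

Compound 1 `N#Cc1ccc(-c2cc(COC(Cc3cn(C4CCN(Cc5ccc([N+](=O)[O-])cc5)CC4)nn3)c3ccc(Br)cc3)on2)cc1`: > 25000 nM in a functional assay on MDA-MB-231 cells (Homo sapiens) for cytotoxicity, with a stated time of 48 h; a higher number here means a weaker inhibitor, a lower number a stronger inhibitor (a limit of the assay)
Compound 2 `O=[N+]([O-])c1ccc(CN2CCC(n3cc(CC(OCc4cc(-c5cccc(F)c5)no4)c4ccc(Br)cc4)nn3)CC2)cc1`: 5000 nM in this assay
Compound 3 `O=[N+]([O-])c1ccc(CN2CCC(n3cc(CC(OCc4cc(-c5ccccc5Br)no4)c4ccc(Br)cc4)nn3)CC2)cc1`: > 25000 nM in this assay (a limit of the assay)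

Compound 3 therefore sits at the ceiling of this assay, and only a floor for its number is known. Compound 4 `O=[N+]([O-])c1ccc(CN2CCC(n3cc(CC(OCc4cc(-c5ccccc5F)no4)c4ccc(Br)cc4)nn3)CC2)cc1` differs from it by fluoro in place of bromo on an aromatic carbon. Within the data shown here, no measured step makes exactly this exchange. The nearest is an at least 5.0-fold higher number from compound 2 to compound 3 (0.69 log units; beyond the scatter), a clear loss; a step that the two limits leave unreadable from compound 1 to compound 3 cannot be read, and the limit of > 25000 nM in this assay, at which 2 of the 3 values shown sit, shows where two of the three values end. Compound 4 carries the fluoro of compound 2 at the place of the bromo in compound 3, so a number somewhere between those two is expected, quite possibly again only a limit. For compound 4 the estimate is 15000 nM, within 5000 nM to 40000 nM. That would mean an at least 1.6-fold lower number from compound 3 to compound 4 (0.22 log units; that floor lies within the scatter), an expected step that is uncertain.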

Compound 4, half-maximal inhibitory concentration: 4000 nM
Beside the measured number, compound 4's estimate is 3.8-fold (0.57 log units) above it, and the stated range ends above it.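

In this assay, fluoro in place of bromo on this ring gives an at least 6.2-fold lower number from compound 3 to compound 4 (0.79 log units; beyond the scatter), so this place can carry a halogen without the loss seen with 2-bromophenyl. Moving the fluoro makes no readable difference, with a 1.3-fold lower number from compound 2 to compound 4 (0.10 log units; within the scatter). The 2-fluorophenyl group also improves on 4-cyanophenyl, with an at least 6.2-fold lower number from compound 1 to compound 4 (0.79 log units; beyond the scatter), which matches what 3-fluorophenyl showed.

On these data alone, whether chloro or methoxy at this place would behave like fluoro or like bromo stays open. So does 4-fluorophenyl, which would show whether the nitrile or the position of the group accounts for the weak result of compound 1.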